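A few compounds are considered here, and "the series" means these few. Any claim that something is new, unique, unknown or untested is made for them only; others in the source may bear on it.

Three measured compounds share one core and differ in the amide attached to the aniline nitrogen. Compound 1 `O=C(CN1CCCC1)Nc1ccc(-c2nc3cc(C(F)(F)F)ccc3[nH]2)cc1` carries a pyrrolidinyl acetamide, compound 2 `O=C(CN1CCN(c2ccccc2)CC1)Nc1ccc(-c2nc3cc(C(F)(F)F)ccc3[nH]2)cc1` a phenylpiperazinyl acetamide, and compound 3 `CC(=O)Nc1ccc(-c2nc3cc([N+](=O)[O-])ccc3[nH]2)cc1` a plain acetamide together with a nitro group where the other two carry trifluoromethyl.

In an ADME assay on MDBK cells (Bos taurus) for cytotoxicity, read by MTT assay, with a stated time of 96 h (a lower number here means that less compound is tolerated, a higher number that more compound is tolerated), compound 1 gives 15000 nM, the lowest of the two numbers recorded. Compound 2 gives 32000 nM, and the gap between the two lies beyond the scatter. For compound 3 the read-out is the limit of > 100000 nM in this assay, at which 1 of the 3 values shown sits, a limit rather than a number, reported as > 100000 nM.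

Compound 4 `O=C(O)CCC(=O)Nc1ccc(-c2nc3cc(C(F)(F)F)ccc3[nH]2)cc1` has not been measured. Set against compound 1, the change is carboxymethyl in place of pyrrolidin-1-yl on a saturated chain carbon bound to a carbonyl carbon. Going by the values given here, no measured pair shows this exchange, so the direction has to be judged from the change itself. The expectation is a step upward from compound 1 of a 2.7-fold higher number from compound 1 to compound 4 (0.43 log units; beyond the scatter), beyond the scatter but not large. Compound 4 is therefore estimated at 40000 nM in this assay, with a range from 12000 nM to 100000 nM, and there is a real chance the assay reports only a limit.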

Compound 4, half-maximal cytotoxic concentration: > 100000 nM
Compound 4 gave a limit, no number; the forecaster's own chance of this, stated with the estimate: 35%; at least 2.5-fold (0.39 log units) between middle value and limit.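

The exchange at this position, on a saturated chain carbon bound to a carbonyl carbon, moves the result in this assay well beyond the scatter, with an at least 6.6-fold higher number from compound 1 to compound 4 (0.82 log units; beyond the scatter). Going by these compounds alone, until now, the two compounds carrying trifluoromethyl, compound 1 and compound 2, had both given numbers, so this is the first sign that a compound with trifluoromethyl can reach the top of the assay's range through a change at this position alone. The result for compound 4 is a limit and not a number, so the step has a lower bound but no known size: the limit of > 100000 nM in this assay, at which 2 of the 4 values shown sit.

The exchange removes the five-membered ring and its nitrogen and brings in an open chain ending in a carboxylic acid, all in one move, so the compounds shown cannot say whether losing the ring, losing the amine or gaining the acid accounts for the step. An open-chain dimethylamino group, which keeps the amine without the ring, or a methyl ester in place of the acid, which keeps the chain without its hydrogen-bond donor, would begin to separate these parts.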